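The source may hold more compounds than are shown below. What is called first, only, known or untested is meant among the compounds shown, and "the series" means these compounds.

In an ADME assay on FSCLL cells (Homo sapiens) for cytotoxicity, read by MTT assay, with a stated time of 24 h (on this read-out lower numbers stand for higher toxicity in this test and higher numbers for lower toxicity in this test), compound 1 `CC(C)C[C@H](NC(=O)[C@@H](N)CO)B(O)O` gives 1700 nM, which stands as the lower of the two numbers in hand, though the gap to compound 2 is within the scatter. Among the measured compounds shown here, compound 2 `CC(C)C[C@H](NC(=O)[C@@H](N)[C@@H](C)O)B(O)O` gives 2500 nM, and the only measured step, a 1.5-fold higher number from compound 1 to compound 2 (0.17 log units; within the scatter), does not leave the scatter. Compound 3 `CC(C)C[C@H](NC(=O)CN)B(O)O` differs from compound 1 by hydrogen in place of hydroxymethyl on a saturated chain carbon bound to an amine nitrogen and a carbonyl carbon. For the measured compounds named here, the one step available touched this same part of the shared core and moved the number no further than the scatter, so nothing beyond the scatter is expected here in either direction. Compound 3 is therefore expected to give 2000 nM, between 800 nM and 5000 nM, a step of a 1.2-fold higher number from compound 1 to compound 3 (0.07 log units; within the scatter).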

Compound 3, half-maximal cytotoxic concentration: 670 nM
For compound 3 the middle estimate is 3.0-fold (0.47 log units) above the measured one; measured number below the stated range.
By their numbers in this assay, from the lowest: compound 3; then compounds 1 and 2 (each within the scatter of the next).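

In this assay, the substituent on the saturated chain carbon bound to an amine nitrogen and a carbonyl carbon proves to matter: hydrogen in place of hydroxymethyl gives a 2.5-fold lower number from compound 1 to compound 3 (0.40 log units; beyond the scatter), and hydrogen in place of 1-hydroxyethyl gives a 3.7-fold lower number from compound 2 to compound 3 (0.57 log units; beyond the scatter). Adding methyl to the substituent had left the number within the scatter, whereas removing the whole substituent takes it beyond the scatter, toward higher toxicity in this test. No evidence at hand explains this change. Going by these compounds, whether a methyl group at this place would stay with compound 1 or with compound 3 remains open, as does the outcome with an amine or a carboxylic acid there.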